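The compounds below may be only part of what the source reports. "The series", "measured", "known", "first", "only" and "open" are said of these compounds alone.

Measured compounds: compound 1 `CS(=O)(=O)c1cccc(S(=O)(=O)c2ccc3c(c2)CCC[C@H]3CN)c1` gives 3.98 nM in an assay on isolated protein for displacement of a labelled ligand from 5-hydroxytryptamine receptor 6 (Homo sapiens); a higher number here means a weaker inhibitor, a lower number a stronger inhibitor; compound 2 `O=C1CN=C(NC[C@@H]2CCCc3cc(S(=O)(=O)c4cccc(F)c4)ccc32)N1` gives 0.1 nM; compound 3 `O=C(NC[C@@H]1CCCc2cc(S(=O)(=O)c3cccc(F)c3)ccc21)c1ccc[nH]1` gives 5.01 nM.

Compound 3 has the highest number of the three, close to compound 1 and far from compound 2. Compound 4 `CN(CC(N)=O)C[C@@H]1CCCc2cc(S(=O)(=O)c3cccc(F)c3)ccc21` is reached from compound 3 by the change ((carbamoylmethyl)(methyl)amino in place of ((1H-pyrrol-2-yl)carbonyl)amino on a saturated chain carbon bound to a saturated ring carbon). Among the measured compounds shown here, the one measured step on this nitrogen, a 50-fold higher number from compound 2 to compound 3 (1.70 log units; beyond the scatter), shows that what hangs on the amine can move the number far, but that step does not reproduce the present change. Compound 1, with a bare amine, and compound 3 show values within the scatter of each other, so the chain-bearing amine of compound 4 is expected to lie in the same region, with a 1.4-fold lower number from compound 3 to compound 4 (0.16 log units; within the scatter) small. Compound 4 is estimated at 3.5 nM, between 0.8 nM and 15 nM.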

Compound 4, inhibition constant: 1.26 nM
Compound 4: the middle estimate sits 2.8-fold (0.44 log units) above what was measured; the range from low to high includes it.
By their numbers in this assay, from the lowest: compound 2; then compound 4; then compounds 1 and 3 (each within the scatter of the next).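

With a 4.0-fold lower number from compound 3 to compound 4 (0.60 log units; beyond the scatter) as its step, the result shows that on a saturated chain carbon bound to a saturated ring carbon, a group with no ring can replace ((1H-pyrrol-2-yl)carbonyl)amino and still lower the number beyond the scatter. The group with the five-membered non-aromatic ring keeps a clear lead over this ringless group, with a 13-fold higher number from compound 2 to compound 4 (1.10 log units; beyond the scatter) as the step between them. No measurement offered here explains either step. Going by these compounds, whether the methyl or the carbamoylmethyl carries the gain stays open, as does the effect of a carboxylic acid or a longer chain in place of the carbamoyl group.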